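Adding a Chloro Group to the Phenyl of Compound 1

This account rests on a few compounds, and the source may have more. Where it says the series, first, only, none or still open, it means among the compounds named here.

Measured in a functional assay on A549 cells (Homo sapiens) for antiproliferative activity, read by MTT assay, with a stated time of 48 h; on this read-out higher numbers stand for weaker inhibition and lower numbers for stronger inhibition:
Compound 1 `Fc1ccc2[nH]c(-c3cn(-c4ccccc4)nc3-c3ccccc3)nc2c1`: 1720 nM
Compound 2 `Cc1ccc2[nH]c(-c3cn(-c4ccccc4)nc3-c3ccccc3)nc2c1`: 3610 nM
Compound 3 `O=C(OCc1ccccc1)c1ccc2[nH]c(-c3cn(-c4ccccc4)nc3-c3ccccc3)nc2c1`: 19300 nM

Compound 1 holds the lowest number of these three, so it is the strongest inhibitor among them. Compound 4 `Fc1ccc2[nH]c(-c3cn(-c4ccccc4)nc3-c3ccc(Cl)cc3)nc2c1` differs from it in one place: chloro in place of hydrogen on an aromatic carbon, which turns phenyl to 4-chlorophenyl.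

Within the data shown here, two measured steps bear on this only loosely: a 2.1-fold higher number from compound 1 to compound 2 (0.32 log units; beyond the scatter), which is modest, and an 11-fold higher number from compound 1 to compound 3 (1.05 log units; beyond the scatter), which is large. Both replace the fluoro group, and neither alters a phenyl, so they set no direction. The expected outcome is a 1.1-fold lower number from compound 1 to compound 4 (0.06 log units; within the scatter), a change within the scatter. For compound 4 the estimated value is 1500 nM, with an expected range of 600 nM to 4000 nM.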

Compound 4, half-maximal inhibitory concentration: 4610 nM
Estimate against measurement, compound 4: 3.1-fold (0.49 log units) below; measured number above the stated range.
By their numbers in this assay, from the lowest: compound 1; then compounds 2 and 4 (each within the scatter of the next); then compound 3.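

Compound 4 shows that this phenyl does not tolerate every change: in this assay, going from phenyl to 4-chlorophenyl gives a 2.7-fold higher number from compound 1 to compound 4 (0.43 log units; beyond the scatter). Among these compounds, the earlier steps touched only the fluoro group, so this is the first sign that a single added chlorine on the phenyl also moves the number upward, and compound 1 remains the strongest inhibitor of the set. Nothing available explains this shift. From the compounds shown here alone, whether a methoxy group, an amine or a carboxylic acid at this place would give a similar step stays open, as does the effect of a chloro group on the other phenyl.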